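Methoxy in Place of Hydrogen on the Aryl Ring

The compounds below may be only part of what the source reports. "The series", "measured", "known", "first", "only" and "open" are said of these compounds alone.

Compound 2 `O=C(O)COc1ccc(Cl)cc1C#Cc1ccccc1` gives 108 nM in an assay on CHO cells for displacement of a labelled ligand from prostaglandin D2 receptor 2 (Homo sapiens), read by scintillation counting (on this read-out lower numbers stand for stronger inhibition and higher numbers for weaker inhibition), the highest of the three numbers recorded, with compound 1 `CN(C)C(=O)c1cccc(C#Cc2cc(Cl)ccc2OCC(=O)O)c1` at 52 nM and compound 3 `CN(C)S(=O)(=O)c1cccc(C#Cc2cc(Cl)ccc2OCC(=O)O)c1` at 14 nM. Compound 4 `COc1ccccc1C#Cc1cc(Cl)ccc1OCC(=O)O` differs from compound 2 by methoxy in place of hydrogen on an aromatic carbon. The steps that touch this position are a 2.1-fold higher number from compound 1 to compound 2 (0.32 log units; beyond the scatter) and a 7.7-fold lower number from compound 2 to compound 3 (0.89 log units; beyond the scatter), both showing that a substituent in place of hydrogen lowers the number. The methoxy group of compound 4 is smaller than either substituent, and sits ortho to a large group, so a smaller effect is expected. For compound 4 the estimate is 70 nM, with a range of 25 nM to 200 nM, meaning an expected step of a 1.5-fold lower number from compound 2 to compound 4 (0.19 log units; within the scatter).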

Compound 4, inhibition constant: 190 nM
Estimate against measurement, compound 4: 2.7-fold (0.43 log units) below, within the range that was stated.
By their numbers in this assay, from the lowest: compound 3; then compound 1; then compounds 2 and 4 (each within the scatter of the next).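

In this assay, methoxy in place of hydrogen on an aromatic carbon, ortho to a large group, gives a 1.8-fold higher number from compound 2 to compound 4 (0.25 log units; within the scatter), so this change does not separate compound 4 from compound 2. The lower numbers seen with dimethylcarbamoyl and dimethylsulfamoyl in place of hydrogen therefore do not extend to every substituent, and methoxy at this place goes against that trend. Nothing available explains this result. Going by these compounds, whether an amine or ethoxy on this same carbon would move the number remains open, as does how dimethylsulfamoyl would behave there.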